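Adding trifluoromethyl to compound 2: what to expect

A few compounds are considered here, and "the series" means these few. Any claim that something is new, unique, unknown or untested is made for them only; others in the source may bear on it.

In an ADME assay on THP-1 cells (Homo sapiens) for cytotoxicity, read by flow cytometry and propidium iodide staining, with a stated time of 72 h (on this read-out higher numbers stand for weaker inhibition and lower numbers for stronger inhibition), compound 2 `CC(=O)Nc1ccc2oc(-c3ccccc3)cc(=O)c2c1` gives 97000 nM and compound 1 `COc1cccc(/C=C/C(=O)c2cc(NC(C)=O)ccc2O)c1` gives 93700 nM. For the measured compounds named here, these two values lie within the scatter of each other, so they sit level at the top of the three numbers measured so far. Compound 3 `CC(=O)Nc1ccc2oc(-c3ccc(F)cc3)cc(=O)c2c1` gives 22000 nM, the lowest of the three.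

Compound 4 `CC(=O)Nc1ccc2oc(-c3cccc(C(F)(F)F)c3)cc(=O)c2c1` keeps the core of compound 2 and changes it in one place: trifluoromethyl in place of hydrogen on an aromatic carbon. Trifluoromethyl takes the place of hydrogen on an aromatic carbon, meta to a large group.

Going by the values given here, only one measured step bears on this change: a 4.4-fold lower number from compound 2 to compound 3 (0.64 log units; beyond the scatter), a modest step with fluoro in place of hydrogen on an aromatic carbon. That is a different group at a different place, and a single step is a thin guide. A lower number is therefore expected, but with less confidence and probably by a smaller amount.

The estimated change is a 2.8-fold lower number from compound 2 to compound 4 (0.44 log units; beyond the scatter). For compound 4 the expected value in this assay is 35000 nM, with an estimated range from 10000 nM to 100000 nM.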

Compound 4, half-maximal inhibitory concentration: 50000 nM
Estimate against measurement, compound 4: 1.4-fold (0.15 log units) below, and the stated range covers the measured number.
By their numbers in this assay, from the lowest: compound 3; then compounds 4, 1 and 2 (each within the scatter of the next).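

In this assay trifluoromethyl on this aromatic carbon, meta to a large group, gives a 1.9-fold lower number from compound 2 to compound 4 (0.29 log units; within the scatter) and so cannot be told apart from hydrogen there. For the compounds shown here, putting fluorine atoms on this ring therefore does not always lower the number: the only step beyond the scatter remains a 4.4-fold lower number from compound 2 to compound 3 (0.64 log units; beyond the scatter) with fluoro at a different place. Nothing shown here explains why the two steps differ.

On these data alone, because the group and the place both differ between these two steps, it stays open whether the group or the place matters, and fluoro on this same carbon or trifluoromethyl at the place fluoro holds in compound 3 would separate the two. As far as these compounds go, it is also open how a quite different group on this carbon, such as an amine or a carboxylic acid, would behave.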